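Acrylamide-bearing triazine series: replacing the para carbamoyl group

This account rests on a few compounds, and the source may have more. Where it says the series, first, only, none or still open, it means among the compounds named here.

Compound 1 `C=CC(=O)Nc1cccc(Nc2ncnc(Nc3ccc(C(=O)Nc4ccccn4)cc3)n2)c1` is tested in a functional assay on Raji cells (Homo sapiens) for antiproliferative activity, read by CCK-8 assay, with a stated time of 24 h (a higher number here means a weaker inhibitor, a lower number a stronger inhibitor), and gives 15600 nM. Among the three compounds measured so far this is the high end of the numbers. Compound 3 `C=CC(=O)Nc1cccc(Nc2nc(N)nc(Nc3ccc(Oc4ccccc4)cc3)n2)c1` gives 8320 nM, and the gap between compound 1 and compound 3 lies within the scatter, so the two cannot be told apart. Compound 2 `C=CC(=O)N1CCc2ccc(Nc3ncnc(Nc4ccc(C(=O)N5CCCCC5)cc4)n3)cc21` gives 2840 nM, and the gap from compound 1 to compound 2 lies beyond the scatter; compound 2 and compound 3 also differ in other places of the shared core, so no single change accounts for these gaps.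

Compound 4 `C=CC(=O)Nc1cccc(Nc2ncnc(Nc3ccc(OCCOC)cc3)n2)c1` has not yet been measured in this assay. It differs from compound 1 in one place: 2-methoxyethoxy in place of (pyridin-2-yl)carbamoyl on an aromatic carbon. Within the data shown here, no measured pair isolates a change of this kind, so there is no step on record from which to read a direction. The step from compound 1 to compound 4 is expected to be small, probably within the scatter, with no direction that can be called beyond it: a 1.6-fold lower number from compound 1 to compound 4 (0.19 log units; within the scatter). Compound 4 is therefore estimated at 10000 nM, in a range from 3000 nM to 35000 nM.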

Compound 4, half-maximal inhibitory concentration: 105000 nM
Compound 4: the middle estimate sits 11-fold (1.02 log units) below what was measured; measured number outside the range, above it.
By their numbers in this assay, from the lowest: compound 2; then compounds 3 and 1 (each within the scatter of the next); then compound 4.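

Among these compounds, at this position the group is not interchangeable on the core of compound 1: in this assay, putting 2-methoxyethoxy in place of (pyridin-2-yl)carbamoyl on an aromatic carbon, para to a large group, gives a 6.7-fold higher number from compound 1 to compound 4 (0.83 log units; beyond the scatter) and so a weaker inhibitor, the first one-place step on record. The change is not a single one, since the group that leaves has 9 heavy atoms, a six-membered aromatic ring with 1 hetero atom and 1 hydrogen-bond donor, while the group that enters has 5 heavy atoms, no ring and 0 hydrogen-bond donors, with the count of hydrogen-bond acceptors the same on both sides. No measurement on these compounds speaks to what lies behind the step.

Still open, from the compounds shown here alone, is which part of the departing group matters, the pyridine ring, its ring nitrogen or the amide hydrogen, which a phenylcarbamoyl group or a plain carboxamide at this place would help to separate. Also open, going by these compounds, is how the ether side behaves when varied on its own, for instance with a longer alkoxy chain or a 2-(dimethylamino)ethoxy chain on the same carbon.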